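Trimming a Hydroxymethyl Group: Expected Cytotoxicity on Endothelial Cells

This account rests on a few compounds, and the source may have more. Where it says the series, first, only, none or still open, it means among the compounds named here.

Compound 1 `CC1=C([Se]CC(OC(=O)[C@@H](CO)NC(=O)OC(C)(C)C)C(=O)NCCCCCC(=O)OCc2ccccc2)C(=O)c2ccccc2C1=O`: 35000 nM
Compound 2 `CC1=C(SCCC(=O)OC(C[Se]c2ccccc2)C(=O)NCCCCCC(=O)OCc2ccccc2)C(=O)c2ccccc2C1=O`: 23000 nM

In an ADME assay on HUVEC cells (Homo sapiens) for cytotoxicity, read by MTT assay, with a stated time of 24 h (on this read-out lower numbers stand for stronger inhibition and higher numbers for weaker inhibition), compound 1 gives 35000 nM, the higher of the two numbers shown, and compound 2 gives 23000 nM; the two lie within the usual scatter of each other. Compound 3 `CC1=C([Se]CC(OC(=O)CNC(=O)OC(C)(C)C)C(=O)NCCCCCC(=O)OCc2ccccc2)C(=O)c2ccccc2C1=O` differs from compound 1 by hydrogen in place of hydroxymethyl on a saturated chain carbon bound to an amide-type nitrogen and a carbonyl carbon. Going by the values given here, no step between measured compounds is known here, so nothing measured tells how such a change moves the number. The expected step of a 1.1-fold lower number from compound 1 to compound 3 (0.04 log units; within the scatter) is therefore none beyond the scatter. Compound 3 is expected at 32000 nM, with a range from 12000 nM to 85000 nM.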

Compound 3, half-maximal inhibitory concentration: 36000 nM
Compound 3: the middle estimate sits 1.1-fold (0.05 log units) below what was measured; the range from low to high includes it.
By their numbers in this assay, from the lowest: compounds 2, 1 and 3 (each within the scatter of the next).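

In this assay, replacing the hydroxymethyl group with hydrogen on a saturated chain carbon bound to an amide-type nitrogen and a carbonyl carbon gives a 1.0-fold higher number from compound 1 to compound 3 (0.01 log units; within the scatter). This first measured step at this position shows that, for this pair, losing the hydroxymethyl group, with its hydrogen-bond donor and acceptor, leaves the number within the scatter. No available evidence explains this result. On these data alone, whether a methyl group, an amine or a carboxylic acid at this position would also stay within the scatter remains open.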